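A few compounds are considered here, and "the series" means these few. Any claim that something is new, unique, unknown or untested is made for them only; others in the source may bear on it.

Among the compounds with values here, in a functional assay on HeLa cells (Homo sapiens) for cytotoxicity (on this read-out lower numbers stand for stronger inhibition and higher numbers for weaker inhibition), compound 3 `CCOC1=CC(=O)c2ccccc2C1=O` gives 23800 nM, the lowest of the three numbers so far. Compound 1 `CCCOC1=CC(=O)c2ccccc2C1=O` gives 51600 nM and compound 2 `CC(=O)OC1=CC(=O)c2ccccc2C1=O` gives 62100 nM. Compound 4 `CS(=O)(=O)OC1=CC(=O)c2ccccc2C1=O` is still to be measured. It differs from compound 3 as follows: methylsulfonyl in place of ethyl on an oxygen on an unsaturated carbon. Within the data shown here, no measured compound carries methylsulfonyl, so the guidance is indirect. Among the measured compounds shown here, the closest precedent is compound 2, with acetyl on that oxygen, which shows a 2.6-fold lower number from compound 2 to compound 3 (0.42 log units; beyond the scatter). Alongside it stand a 2.2-fold lower number from compound 1 to compound 3 (0.34 log units; beyond the scatter) and a 1.2-fold higher number from compound 1 to compound 2 (0.08 log units; within the scatter). Both of the larger steps leave ethyl with the lower number, so a modest move upward is expected. The expected step is a 1.9-fold higher number from compound 3 to compound 4 (0.28 log units; within the scatter). Compound 4 is estimated at 45000 nM, within an expected range of 18000 nM to 110000 nM.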

Compound 4, half-maximal inhibitory concentration: 7610 nM
Estimate against measurement, compound 4: 5.9-fold (0.77 log units) above, and the stated range ends above it.
By their numbers in this assay, from the lowest: compound 4; then compound 3; then compounds 1 and 2 (each within the scatter of the next).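

On this oxygen on an unsaturated carbon, methylsulfonyl gives a lower number than ethyl, acetyl or propyl, with a 3.1-fold lower number from compound 3 to compound 4 (0.50 log units; beyond the scatter) and an 8.2-fold lower number from compound 2 to compound 4 (0.91 log units; beyond the scatter) and a 6.8-fold lower number from compound 1 to compound 4 (0.83 log units; beyond the scatter). In this assay the lowest number therefore no longer belongs to ethyl, and compound 4 lies beyond the scatter of all three other compounds. No measured evidence bears on the reason for this result. Going by these compounds, what remains open is how a free hydroxyl, a methyl or a phenylsulfonyl group on this oxygen would compare with methylsulfonyl.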